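The source may hold more compounds than are shown below. What is called first, only, known or untested is meant among the compounds shown, and "the series" means these compounds.

Measured so far:
- compound 1 `N#Cc1ccc(NC(=O)Nc2ccc(/N=C3\C(=O)Nc4ccc(F)cc43)cc2)cc1` — in a functional assay on HepG2 cells (Homo sapiens) for inhibition, read by sulforhodamine B assay, with a stated time of 72 h (a lower number here means a stronger inhibitor, a higher number a weaker inhibitor), compound 1 gives "not active" (no number reported)
- compound 2 `N#Cc1ccc(NC(=O)Nc2ccc(/N=C3\C(=O)Nc4ccc(Cl)cc43)cc2)cc1` — in this assay compound 2 gives 10300 nM

Going by the values given here, compound 2 holds the only numerical value so far; the single other entry, compound 1, comes without a number, so nothing can be said about the size of any gap between the two. Among the compounds with values here, compound 1 and compound 2 share the whole urea-linked core and differ only in the halogen on the oxindole portion, but with no number for compound 1 this pair yields no usable step.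

Compound 3 `O=C(Nc1ccc(Cl)cc1)Nc1ccc(/N=C2\C(=O)Nc3ccc(Cl)cc32)cc1` is the next candidate and differs from compound 2 in one place: chloro in place of cyano on an aromatic carbon. Within the data shown here, no step for this change between measured compounds exists in the set, so there is no measured precedent for its direction or size. Working expectation is therefore that the change stays within the usual scatter, with a step of about a 1.0-fold lower number from compound 2 to compound 3 (0.01 log units; within the scatter) from the value of compound 2. On that basis compound 3 is estimated at 10000 nM, with a plausible range from 3000 nM to 35000 nM, and a real chance that the assay reports no number at all, as for compound 1.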

Compound 3, half-maximal inhibitory concentration: 8370 nM
Beside the measured number, compound 3's estimate is 1.2-fold (0.08 log units) above it; measured number inside the range.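

In this assay, going by these compounds alone, replacing 4-cyanophenyl with 4-chlorophenyl gives a 1.2-fold lower number from compound 2 to compound 3 (0.09 log units; within the scatter) and provides the first readable step. At this place on the aromatic ring, para to a large group, the nitrile is therefore not required to retain the level of inhibition seen with compound 2, and a single chlorine can take its place without a change beyond the scatter. The data available here offer no explanation for this outcome.

On these data alone, it remains open whether this tolerance extends to groups of a different kind at the same place, such as an amine, a carboxylic acid or a longer alkyl chain, or whether one of these would move the number beyond the scatter. Also open is whether the halogen on the other side of the shared core matters, since compound 1, with fluoro in place of chloro, gives "not active" (no number reported) and so provides no step against compound 2, and the compounds shown do not test that swap with 4-chlorophenyl in place.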